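The compounds below may be only part of what the source reports. "The series", "measured", "known", "first", "only" and "open" are said of these compounds alone.

Compound 3 `COc1cc(Cl)cc(-c2nn(-c3cccc(NC(=O)Nc4cc(C(F)(F)F)cc(C(F)(F)F)c4)c3)cc2-c2ccncc2)c1` shows the lowest of the three numbers in a functional assay on SR cells (Homo sapiens) for inhibition, read by sulforhodamine B assay, with a stated time of 48 h, tested at 10 uM (a lower number here means a stronger effect, a higher number a weaker effect of the compound at the concentration tested), giving -37.9%. Nearest to it is compound 1 `O=C(Nc1cccc(-n2cc(-c3ccncc3)c(-c3cc(O)cc(Cl)c3)n2)c1)Nc1ccc(Cl)c(C(F)(F)F)c1`, which gives -30.6%, a gap within the scatter. Furthest is compound 2 `COc1cc(Cl)cc(-c2nn(-c3cccc(NC(=O)Nc4ccc(Cl)c(C(F)(F)F)c4)c3)cc2-c2ccncc2)c1`, which gives -27.5%, a gap beyond the scatter. Compound 4 `COc1cc(Cl)cc(-c2nn(-c3cccc(NC(=O)Nc4cccc(C(F)(F)F)c4)c3)cc2-c2ccncc2)c1` differs from compound 3 by hydrogen in place of trifluoromethyl on an aromatic carbon. Going by the values given here, the only measured step, a number 3.1 percentage points higher from compound 1 to compound 2 (within the scatter), concerns methyl in place of hydrogen on an oxygen and so does not bear on the loss of a trifluoromethyl; no measured step does. With nothing pointing to a direction, no change beyond the scatter is expected, and compound 4 is estimated at -30%, between -50% and -5%. This amounts to an expected step of a number 7.9 percentage points higher from compound 3 to compound 4 (within the scatter).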

Compound 4, a percentage reported as activity, at one concentration (the size of the read-out at that concentration, not a potency): -13.5%
For compound 4 the middle estimate is 16.5 percentage points below the measured one; low and high end bracket the measured number.
By their numbers in this assay, from the lowest: compounds 3, 1 and 2 (each within the scatter of the next, the first and the last beyond it); then compound 4.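

In this assay, going by these compounds alone, the only earlier step concerned the oxygen, whereas hydrogen in place of trifluoromethyl on an aromatic carbon gives a clear loss of effect (a number 24.4 percentage points higher from compound 3 to compound 4 (beyond the scatter)), showing that this position matters. Hydrogen in place of chloro on an aromatic carbon also weakens the effect (a number 14 percentage points higher from compound 2 to compound 4 (beyond the scatter)), so on this ring either group goes with a stronger effect than hydrogen. Nothing available explains these steps. On these data alone, whether a nitrile or an amine on this carbon would keep the effect stays open.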